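Piperidin-1-yl for pyrrolidin-1-yl in an inactive pair

The source may report more compounds than this note shows. Statements on the series, on what has been measured and on what is new or still open speak of the compounds shown alone.

In a functional assay on PC-3 cells (Homo sapiens) for cytotoxicity, read by MTT assay, with a stated time of 72 h (on this read-out lower numbers stand for stronger inhibition and higher numbers for weaker inhibition), compound 1 (`CSc1nc(Cl)c(C(=O)c2ccccc2)s1`) gives > 100000 nM, which is a limit of the assay and not a number. Compound 2 (`O=C(c1ccccc1)c1sc(N2CCCC2)nc1Cl`) gives > 100000 nM, which is likewise a limit. Neither compound therefore has a measured potency, and the position of the pair is summed up as the limit of > 100000 nM in this assay, at which 2 of the 2 values shown sit.

Compound 3 (`O=C(c1ccccc1)c1sc(N2CCCCC2)nc1Cl`) carries piperidin-1-yl in place of pyrrolidin-1-yl on an aromatic carbon. Among the measured compounds shown here, the one measured step that bears on this change, a step that the two limits leave unreadable from compound 1 to compound 2, is also a swap on an aromatic carbon, but its size cannot be read, so it offers no size to carry over. The expectation for compound 3 therefore rests on compound 2 at > 100000 nM, a limit. The estimated step is a number no higher from compound 2 to compound 3 (the limit leaves the size open), and no shift beyond the usual scatter is expected in this assay, so another reported limit is the likeliest outcome. For compound 3 the estimated value is 100000 nM, with an expected range of 40000 nM to 200000 nM.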

Compound 3, half-maximal inhibitory concentration: 69000 nM
Compound 3: middle estimate off by 1.4-fold (0.16 log units), on the high side; the range from low to high includes it.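

In this assay, among the compounds shown here, compound 3 gives 69000 nM, the first reading that is a number and not a limit, so this position can carry a group that gives a measurable value. Piperidin-1-yl in place of pyrrolidin-1-yl comes with an at least 1.4-fold lower number from compound 2 to compound 3 (0.16 log units; that floor lies within the scatter), and piperidin-1-yl in place of methylsulfanyl comes with an at least 1.4-fold lower number from compound 1 to compound 3 (0.16 log units; that floor lies within the scatter); each is only a floor set by a limit and lies within the usual scatter, so neither establishes a real difference, and the step from compound 1 to compound 2 cannot be read. The series as shown remains mostly at the assay's limit: the limit of > 100000 nM in this assay, at which 2 of the 3 values shown sit.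

The compounds shown leave open whether any group at this position moves the value clear of the scatter, for example morpholin-4-yl, piperazin-1-yl with its free ring amine, or an open-chain dimethylamino group. They also leave open what replacing the chloro group on the ring would do with piperidin-1-yl held in place, for instance with a methoxy group or a nitrile.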